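A few compounds are considered here, and "the series" means these few. Any claim that something is new, unique, unknown or untested is made for them only; others in the source may bear on it.

Measured so far in a physicochemical assay for solubility, at pH 7.4; a higher number here means a more soluble compound, a lower number a less soluble compound:
- compound 1 `Cc1cc(NC(=O)Nc2ccc(F)c(F)c2)c2ccccc2n1`: 500 nM
- compound 2 `Cc1cc(NC(=O)Nc2ccc(F)cc2)c2ccccc2n1`: 3700 nM
- compound 3 `Cc1cc(NC(=O)Nc2ccc(F)cc2F)c2ccccc2n1`: 3000 nM

Of these three, compound 2 has the highest number, though compound 3 sits within the scatter of it, and only compound 1 lies clearly lower. The step from compound 1 to compound 2 removed a fluoro from the aromatic ring and gave a 7.4-fold higher number from compound 1 to compound 2 (0.87 log units; beyond the scatter). The step from compound 2 to compound 3 added a fluoro at another spot of the same ring and gave a 1.2-fold lower number from compound 2 to compound 3 (0.09 log units; within the scatter).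

Compound 4 `Cc1cc(NC(=O)Nc2ccc(Cl)cc2)c2ccccc2n1` differs from compound 2 in one place: chloro in place of fluoro on an aromatic carbon. Among the measured compounds shown here, no measured step swaps one halogen for another, so the two steps above bear on it only loosely: they show that changing a single halogen on this ring can move solubility by a modest amount or leave it within the scatter. Taking both into account, compound 4 is expected to sit somewhat below compound 2, though the shift may not exceed the scatter. The expected step is a 2.1-fold lower number from compound 2 to compound 4 (0.31 log units; beyond the scatter). For compound 4 the estimate in this assay is 1800 nM, with a likely range from 600 nM to 5000 nM.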

Compound 4, solubility: 1400 nM
For compound 4 the middle estimate is 1.3-fold (0.11 log units) above the measured one; measured number inside the range.
By their numbers in this assay, from the lowest: compound 1; then compound 4; then compounds 3 and 2 (each within the scatter of the next).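

In this assay, the change from 4-fluorophenyl to 4-chlorophenyl gives a 2.6-fold lower number from compound 2 to compound 4 (0.42 log units; beyond the scatter). The earlier steps shown here only added or removed a fluoro, whereas this one keeps a halogen at the same place, para to a large group, and changes only which halogen it is; one heavy atom replaces one heavy atom, with no hydrogen-bond donor, acceptor or net charge entering or leaving, and the number still moves beyond the scatter. So this position responds to the identity of the halogen as well as to whether a halogen is present, although nothing available here explains why the number moves this way.

As far as these compounds go, whether this position tolerates groups of a different kind remains open, since a single halogen swap says nothing about how a methoxy, an amine or a carboxylic acid in the same place would read. From the compounds shown here alone, it is also open whether chloro in place of fluoro would give a step of similar size on the rings of compound 1 and compound 3, which carry a second fluoro.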